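The source may report more compounds than this note shows. Statements on the series, on what has been measured and on what is new or still open speak of the compounds shown alone.

In a functional assay on HEL cells (Homo sapiens) for cytotoxicity (a higher number here means that more compound is tolerated, a lower number that less compound is tolerated), compound 1 `CO[C@@H]1[C@@H](OC)[C@H](Cc2ccccc2)O[C@@H]2CO[C@@H](c3ccccc3)O[C@@H]12` gives 20 ug/mL. Compound 2 `CO[C@@H]1[C@@H](OC)[C@H](c2ccccc2)O[C@@H]2CO[C@@H](c3cccs3)O[C@@H]12` has no number in this assay: for compound 2 the entry reads "not determined" (no result reported), so where it stands cannot be read off. Compound 3 `CO[C@@H]1[C@@H](OC)[C@H](c2ccccc2)O[C@@H]2CO[C@@H](c3ccc(Cl)cc3)O[C@@H]12` differs from compound 2 in one place: 4-chlorophenyl in place of thiophen-2-yl on a saturated ring carbon. Among the compounds with values here, no measured pair of compounds shows a change of this kind, so the step from compound 2 to compound 3 in this assay is expected to be small and to stay within the scatter, with no direction that can be given in advance. For compound 3 the estimate in this assay is 20 ug/mL, expected to fall between 7 ug/mL and 60 ug/mL.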

Compound 3, minimum cytotoxic concentration: >= 100 ug/mL
Compound 3: a limit, no number; the forecaster's own chance of this, stated with the estimate: 30%; middle value at least 5.0-fold (0.69 log units) away from the limit.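

In this assay no step can be read from compound 2 to compound 3: compound 2 has no number. Compound 3 gives >= 100 ug/mL, which is a limit. The compounds shown leave open how thiophen-2-yl and 4-chlorophenyl compare on the shared core.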